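The compounds below may be only part of what the source reports. "The series", "measured", "known", "first", "only" and "open" are said of these compounds alone.

For the measured compounds named here, compound 1 `CC1(C)[C@H](c2cc(Cl)cc(Cl)c2)[C@H]1c1c[nH]c(N)n1` is the one compound here with a number in a functional assay on AP1 cells for inhibition of sodium/hydrogen exchanger 1 (Homo sapiens) (a higher number here means a weaker inhibitor, a lower number a stronger inhibitor), where compound 1 gives 180 nM. Compound 2 `CC1(C)[C@H](c2cnc(N)s2)[C@H]1c1cccc2c1CCO2` reaches only a limit of the assay in this assay, with compound 2 recorded as > 30000 nM. The step to compound 3 `CC1(C)[C@H](c2cc(Cl)cc(Cl)c2)[C@H]1c1c[nH]cn1` is the change (hydrogen in place of amino on an aromatic carbon), hydrogen in place of amino on an aromatic carbon. With no measured step of this kind shown, the expectation for compound 3 is a loss in this assay beyond the scatter, a step of a 28-fold higher number from compound 1 to compound 3 (1.44 log units; beyond the scatter). Compound 3 is therefore estimated at 5000 nM, within 1000 nM to 30000 nM.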

Compound 3, half-maximal inhibitory concentration: 4000 nM
The estimate for compound 3 lay 1.3-fold (0.10 log units) above the measured number; measured number inside the range.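

In this assay, for the compounds shown here, removing the amino from the aromatic carbon between two ring nitrogen atoms gives a 22-fold higher number from compound 1 to compound 3 (1.35 log units; beyond the scatter), the first measured step at this position. On the core of compound 1, the amino therefore counts for much of the inhibition, yet compound 3 still gives a number, 4000 nM, so inhibition does not vanish without it. Nothing shown here gives a cause for this loss. Still open, going by these compounds, is whether a methyl or a methylamino group on this carbon would stay near compound 1 or fall towards compound 3.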